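The source may report more compounds than this note shows. Statements on the series, on what has been measured and on what is new or still open speak of the compounds shown alone.

Compound 1 `COc1ccc(-c2cc3ccccc3c(-c3cccc(OC)c3)n2)cc1` sets the starting point in an ADME assay on MCF-10A cells (Homo sapiens) for cytotoxicity, read by CCK-8 assay and cell counting, with a stated time of 72 h; a higher number here means a weaker inhibitor, a lower number a stronger inhibitor. In this assay compound 1 gives > 50000 nM, a limit of the assay rather than a number. Compound 2 `COc1ccc(-c2cc3cc(C)ccc3c(-c3cccc(O)c3)n2)cc1OC` carries a hydroxyl on one outer ring and a methyl on the core, and in this assay compound 2 gives 13500 nM. Compound 3 `COc1cccc(-c2nc(-c3ccc(OC)c(OC)c3)cc3cc(C)ccc23)c1` differs from compound 2 by a methyl on that oxygen; in this assay compound 3 gives > 50000 nM, again only a limit. Among the compounds with values here, the single measured step, an at least 3.7-fold higher number from compound 2 to compound 3 (0.56 log units; beyond the scatter), is thus the sole guide, and compound 3 stands at the weak end of what the three numbers show.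

Compound 4 `COc1ccc(-c2cc3cc(C)ccc3c(-c3cccc(N)c3)n2)cc1OC` is reached from compound 3 by amino in place of methoxy on an aromatic carbon. That change returns a hydrogen-bond donor to the same ring, as compound 2 has, and compound 2 gives 13500 nM in this assay. A move back toward a measurable number is therefore expected, an at least 1.6-fold lower number from compound 3 to compound 4 (0.22 log units; that floor lies within the scatter), though a limit remains possible. For compound 4 the estimate is 30000 nM, with a range from 10000 nM to 90000 nM.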

Compound 4, half-maximal inhibitory concentration: 5600 nM
Estimate against measurement, compound 4: 5.4-fold (0.73 log units) above; measured number outside the range, below it.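

In this assay, replacing 3-methoxyphenyl with 3-aminophenyl gives an at least 8.9-fold lower number from compound 3 to compound 4 (0.95 log units; beyond the scatter), which shows that this place on the ring can return a measurable number with a group other than the hydroxy of compound 2. Amino and hydroxy are also not interchangeable here, with a 2.4-fold lower number from compound 2 to compound 4 (0.38 log units; beyond the scatter), so the identity of the group matters and not only the loss of the methoxy. The value of compound 3 is a limit, so the size of the step out of it is only a floor: the limit of > 50000 nM in this assay, at which 2 of the 4 values shown sit.

On these data alone, whether a methylamino group, an acetamide or a carboxylic acid at this place would move the number further remains open. So does whether amino has a similar effect on the core of compound 1, which lacks the methyl.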